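Urea-bearing analogue of compound 2 in the aorta series

The source may report more compounds than this note shows. Statements on the series, on what has been measured and on what is new or still open speak of the compounds shown alone.

Compound 2 `CCCCc1cccc(=O)n1Cc1ccc(-c2ccccc2-c2nn[nH]n2)cc1` gives 4 nM in a functional assay (aorta) for antagonist activity, with Oryctolagus cuniculus as the target; a higher number here means a weaker inhibitor, a lower number a stronger inhibitor. Of the three measured compounds it stands second highest. Its nearest neighbour is compound 1 `CCCCc1ccc(CN(Cc2ccccc2)S(C)(=O)=O)c(=O)n1Cc1ccc(-c2ccccc2-c2nn[nH]n2)cc1`, which in this assay gives 2 nM, a gap within the scatter. Compound 3 `CCCCc1ccc(CN(Cc2ccccc2)S(=O)(=O)c2ccccc2)c(=O)n1Cc1ccc(-c2ccccc2-c2nn[nH]n2)cc1` gives 20 nM in this assay, beyond the scatter from compound 2. Within the data shown here, the only one-place step recorded is a 10-fold higher number from compound 1 to compound 3 (1.00 log units; beyond the scatter), which concerns the sulfonyl substituent rather than the carbon varied here.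

Compound 4 `CCCCNC(=O)NCc1ccc(CCCC)n(Cc2ccc(-c3ccccc3-c3nn[nH]n3)cc2)c1=O` differs from compound 2 by ((butylcarbamoyl)amino)methyl in place of hydrogen on an aromatic carbon. Among the measured compounds shown here, no measured step covers this change directly. Compounds 1 and 3, which both carry a substituent on the same aromatic carbon, show that such a group can leave the number close to that of compound 2 or can raise it modestly. A similarly small step, if any, is therefore expected for compound 4 in this assay, a 1.3-fold higher number from compound 2 to compound 4 (0.10 log units; within the scatter), leaning toward a slightly higher number. Compound 4 is estimated at 5 nM, with a range from 1.5 nM to 20 nM.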

Compound 4, half-maximal inhibitory concentration: 10 nM
Compound 4: the middle estimate sits 2.0-fold (0.30 log units) below what was measured, within the range that was stated.
By their numbers in this assay, from the lowest: compounds 1 and 2 (each within the scatter of the next); then compounds 4 and 3 (each within the scatter of the next).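

In this assay, ((butylcarbamoyl)amino)methyl in place of hydrogen on this aromatic carbon gives a 2.5-fold higher number from compound 2 to compound 4 (0.40 log units; beyond the scatter), so a substituent at this position now has a step from hydrogen that lies beyond the scatter. Exchanging benzyl(methylsulfonyl)amino for (butylcarbamoyl)amino on the saturated chain carbon gives a 5.0-fold higher number from compound 1 to compound 4 (0.70 log units; beyond the scatter), which shows that the number at this position depends on the group carried on that chain carbon, not only on the presence of a substituent. No available evidence bears on why either step occurs.

Still open, as far as these compounds go, is whether replacing the butyl chain of the urea with an ethyl or a hexyl chain would move the number. Also open, from the compounds shown here alone, is how a plain aminomethyl group or a carboxylic acid on the same aromatic carbon would compare with hydrogen.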